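The source may hold more compounds than are shown below. What is called first, only, known or untested is meant among the compounds shown, and "the series" means these compounds.

Measured compounds in a functional assay on HEp-2 cells (Homo sapiens) for cytotoxicity, read by sulforhodamine B assay, with a stated time of 48 h; a lower number here means a stronger inhibitor, a higher number a weaker inhibitor:

- compound 1 `CC(=O)N1N=C(c2cccc3ccccc23)CC1c1ccccc1` gives 11200 nM
- compound 2 `O=CCN1N=C(c2ccc3ccccc3c2)CC1c1ccccc1[N+](=O)[O-]` gives 3630 nM
- compound 3 `COc1ccc(C2CC(c3ccc4ccccc4c3)=NN2CC=O)cc1OC` gives 1010 nM

Compound 2 stands second highest of the three numbers in this assay. Its nearest neighbour is compound 1, whose number is higher by a margin beyond the scatter; the furthest is compound 3, whose number is lower, again beyond the scatter. Going by the values given here, no two of the measured compounds differ in a single place, so no step between measured compounds can be read off; the values of compound 1 and compound 3 show only that the series spans a spread wider than the scatter.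

Compound 4 `O=CCN1N=C(c2ccc3ccccc3c2)CC1c1cccc(Br)c1` has not yet been measured in this assay. It differs from compound 2 by 3-bromophenyl in place of 2-nitrophenyl on a saturated ring carbon. The measured compounds give no direct guide to this change, as compound 1 and compound 3 each differ from compound 2 in more than one place. With nothing to point in either direction, the step is expected to be small and is likely to stay within the scatter. Compound 4 is therefore expected to give about 3200 nM in this assay, with a range from 1000 nM to 10000 nM. This estimate means an expected step of a 1.1-fold lower number from compound 2 to compound 4 (0.05 log units; within the scatter), which should not exceed the scatter.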

Compound 4, half-maximal inhibitory concentration: 8780 nM
Estimate against measurement, compound 4: 2.7-fold (0.44 log units) below, and the stated range covers the measured number.
By their numbers in this assay, from the lowest: compound 3; then compound 2; then compounds 4 and 1 (each within the scatter of the next).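

In this assay, going by these compounds alone, the saturated ring carbon next to the ring nitrogen responds to a change of aryl group: 3-bromophenyl in place of 2-nitrophenyl gives a 2.4-fold higher number from compound 2 to compound 4 (0.38 log units; beyond the scatter), a modest step and the first single-place comparison. This one step changes both the substituent on the phenyl ring and where it sits, so it cannot be divided between those two differences. No available measurement bears on why the number rises with this exchange.

Going by these compounds, whether the step follows the exchange of substituent or the shift in its place remains open, and a comparison of 2-bromophenyl or 3-nitrophenyl at this carbon with compound 2 and compound 4 would separate the two. The compounds shown also leave open how this carbon would tolerate an aryl group carrying an amine or a carboxylic acid, and whether either would move the number beyond the scatter in this assay.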